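A few compounds are considered here, and "the series" means these few. Any claim that something is new, unique, unknown or untested is made for them only; others in the source may bear on it.

Measured in an ADME assay on microsomes from liver (Mus musculus) for metabolic stability, read by LC-MS, with a stated time of 10 min (a higher number here means that more of the compound is left, a lower number that less of the compound is left), so far:

- compound 1 `CN(C[C@H]1Cc2c(cccc2N2CCN(C3COC3)CC2)CN1)[C@H]1CCCc2cccnc21` gives 50.8%
- compound 2 `CCN1CCN(c2cccc3c2C[C@H](CN(C)[C@H]2CCCc4cccnc42)NC3)CC1` gives 18.8%

Compound 2 stands lowest of the two, and compound 1 lies above it by a margin beyond the scatter. Compound 3 `CN(C[C@H]1Cc2c(cccc2N2C[C@@H]3C[C@H]2CN3)CN1)[C@H]1CCCc2cccnc21` is still unmeasured and differs from compound 2 in one place: a group of 7 heavy atoms (5 carbon, 2 nitrogen; 2 five-membered non-aromatic rings with 1 hetero atom each) in place of a group of 8 heavy atoms (6 carbon, 2 nitrogen; one six-membered non-aromatic ring with 2 hetero atoms), on an aromatic carbon on the shared core. The 4-ethylpiperazin-1-yl group leaves, and with it the ethyl on the ring nitrogen.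

For the measured compounds named here, only one measured step bears on this change, and only indirectly. That step is a number 32 percentage points lower from compound 1 to compound 2 (beyond the scatter) and it is large, with ethyl in place of oxetan-3-yl on an amine nitrogen in a ring. Going by the values given here, no measured compound carries the entering group, so the transfer is uncertain. Compound 3 has no such ethyl, so a rise of moderate size is expected, though less than the full size of that step. The expected step is a number 19.2 percentage points higher from compound 2 to compound 3 (beyond the scatter) and it could still fall within the scatter. For compound 3 the estimate is 38% and the expected range runs from 18% to 62% on this reading.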

Compound 3, percent of the compound remaining: 36.3%
Estimate against measurement, compound 3: 1.7 percentage points above, within the range that was stated.
By their numbers in this assay, from the lowest: compound 2; then compound 3; then compound 1.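

Replacing the whole ring group on the aromatic carbon, and not only the substituent on its ring nitrogen, moves the number in this assay: the group with 2 five-membered non-aromatic rings gives a number 17.5 percentage points higher from compound 2 to compound 3 (beyond the scatter), a modest step beyond the scatter. The same group set against the oxetan-3-yl-bearing piperazine gives a number 14.5 percentage points lower from compound 1 to compound 3 (beyond the scatter), so this position now has three groups with values spread beyond the scatter, and the group of compound 1 remains the highest of them. Nothing measured explains either step, and the size of the changes is all that can be stated here.

The step from compound 2 to compound 3 changes the ring system and removes the ethyl together, so the two contributions cannot be separated; an unsubstituted piperazin-1-yl group on the same aromatic carbon would divide that step into its parts. Also open, as far as these compounds go, is how the free ring nitrogen of compound 3 would read with an oxetan-3-yl or an ethyl placed on it, which would show whether the order seen among the piperazines holds for the entering group.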